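The source may report more compounds than this note shows. Statements on the series, on what has been measured and on what is new or still open speak of the compounds shown alone.

Working notes on the series.

Three compounds share one core and differ in the aryl group attached to the carbonyl carbon. Compound 1 `COc1cc(-c2cc(/C=C/C(=O)c3ccc(N)cc3)[nH]n2)cc(OC)c1OC` carries a 4-aminophenyl there, compound 2 `COc1ccc(-c2cc(/C=C/C(=O)c3ccc(OC)c(OC)c3)[nH]n2)cc1` a 3,4-dimethoxyphenyl together with a different substitution on the other aryl ring, and compound 3 `COc1cc(-c2cc(/C=C/C(=O)c3ccc(Cl)c(Cl)c3)[nH]n2)cc(OC)c1OC` a 3,4-dichlorophenyl. In a functional assay on SNB-19 cells (Homo sapiens) for cytotoxicity, read by sulforhodamine B assay, with a stated time of 48 h, tested at 1 uM (a higher number here means a weaker effect of the compound at the concentration tested, a lower number a stronger effect), compound 1 gives 79%, compound 2 gives 80% and compound 3 gives 90%. Among the compounds with values here, compound 3 thus holds the highest of the three numbers, with compound 2 inside the scatter of it and compound 1 beyond it; the single measured step, a number 11 percentage points higher from compound 1 to compound 3 (beyond the scatter), is modest.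

Compound 4 `COc1ccc(C(=O)/C=C/c2cc(-c3cc(OC)c(OC)c(OC)c3)n[nH]2)cc1` is the next member: 4-methoxyphenyl in place of 3,4-dichlorophenyl on a carbonyl carbon. Within the data shown here, no measured step places a 4-methoxyphenyl against a 3,4-dichlorophenyl on the carbonyl carbon; the step from compound 1 to compound 3 is the only single-place change known, and compound 2, with methoxy groups on that ring, shows a number near those of compound 1 and compound 3. A step of at most modest size is therefore expected in this assay, if anything downward from compound 3, as a number 7 percentage points lower from compound 3 to compound 4 (within the scatter). The estimated value for compound 4 is 83%, within 70% to 95%.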

Compound 4, a percentage reported as activity, at one concentration (the size of the read-out at that concentration, not a potency): 79%
Estimate against measurement, compound 4: 4 percentage points above, within the range that was stated.
By their numbers in this assay, from the lowest: compounds 1, 4, 2 and 3 (each within the scatter of the next, the first and the last beyond it).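

In this assay the aryl group on the carbonyl carbon now has a second single-place change away from 3,4-dichlorophenyl: 4-methoxyphenyl in its place gives a number 11 percentage points lower from compound 3 to compound 4 (beyond the scatter), a step beyond the scatter and of modest size. Methoxy in place of amino on an aromatic carbon gives no change at the digits printed from compound 1 to compound 4 (within the scatter), so among the three compounds with the shared core and this other aryl ring, 3,4-dichlorophenyl is the group that stands apart, while 4-methoxyphenyl and 4-aminophenyl are not told apart. Nothing in hand bears on why the numbers fall this way.

Open, from the compounds shown here alone, is whether a 4-chlorophenyl or an unsubstituted phenyl on the carbonyl carbon would sit with compound 3 or with compound 4. Also open, going by these compounds, is how a carboxylic acid or a dimethylamino group on that ring would read.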